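A few compounds are considered here, and "the series" means these few. Any claim that something is new, unique, unknown or untested is made for them only; others in the source may bear on it.

The series is a set of hydroxamic acids that carry an amide and an acylated amine on the same chain, tested in a functional assay on NFF cells (Homo sapiens) for antiproliferative activity; on this read-out lower numbers stand for stronger inhibition and higher numbers for weaker inhibition. Compound 1 `O=C(CCCCCC(NC(=O)c1cccnc1)C(=O)NCc1ccccc1)NO` gives 24000 nM. Compound 2 `O=C(/C=C/c1ccccc1)N[C@@H](CCCCCC(=O)NO)C(=O)NCc1ccccc1` gives 4010 nM. Compound 3 `CN(C)c1ccc(NC(=O)[C@H](CCCCCC(=O)NO)NC(=O)/C=C/c2ccccc2)cc1` gives 240 nM, the lowest of the three numbers; its nearest neighbour is compound 2, and compound 1 lies furthest from it. Among the compounds with values here, the one step between neighbours, a 17-fold lower number from compound 2 to compound 3 (1.22 log units; beyond the scatter), comes from putting 4-(dimethylamino)phenyl in place of benzyl on the amide-type nitrogen and touches a different part of the molecule from the change now in question.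

Compound 4 `CN(C)c1ccc(NC(=O)[C@H](CCCCCC(=O)NO)NC(=O)c2ccc(C(F)(F)F)cc2)cc1` differs from compound 3 by 4-(trifluoromethyl)phenyl in place of 2-phenylethenyl on a carbonyl carbon. The group leaving is the 2-phenylethenyl with its one double bond outside aromatic rings; the group entering is 4-(trifluoromethyl)phenyl, sitting on the same carbonyl carbon whose other neighbour is the amide-type nitrogen. Within the data shown here, no step among the measured pairs isolates this carbonyl substituent. Compound 1 and compound 2 differ there among other places, and compound 1 shows the higher number, so an aromatic cap without the double bond may carry some cost, though the evidence is indirect. He therefore expects a modest rise, a 2.3-fold higher number from compound 3 to compound 4 (0.36 log units; beyond the scatter), and estimates compound 4 at 550 nM, within 150 nM to 2000 nM.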

Compound 4, half-maximal inhibitory concentration: 400 nM
Estimate against measurement, compound 4: 1.4-fold (0.14 log units) above, and the stated range covers the measured number.
By their numbers in this assay, from the lowest: compounds 3 and 4 (each within the scatter of the next); then compound 2; then compound 1.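

Within the data shown here, this is the first step that isolates the substituent on the carbonyl carbon whose other neighbour is the amide-type nitrogen, and in this assay it reads a 1.7-fold higher number from compound 3 to compound 4 (0.22 log units; within the scatter). With 4-(dimethylamino)phenyl on the amide-type nitrogen, 2-phenylethenyl and 4-(trifluoromethyl)phenyl therefore cannot be told apart on this read-out, and the double bond outside aromatic rings turns out not to be needed to stay in this range, since a ring set directly on the carbonyl carbon does as well within the scatter. No measurement is at hand that would explain this outcome.

The change removes the double bond and brings in the trifluoromethyl at the same time, so the part each plays stays unseparated, and a plain phenyl or a saturated 2-phenylethyl on the same carbonyl carbon would be needed to pull them apart. Also open, as far as these compounds go, is whether the result carries over to compounds with benzyl on the amide-type nitrogen, and how a ring bearing an amine or a carboxylic acid in place of the trifluoromethyl would read.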